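Ethoxy for Methoxy on the Shared Core

A few compounds are considered here, and "the series" means these few. Any claim that something is new, unique, unknown or untested is made for them only; others in the source may bear on it.

Three compounds were measured in a functional assay on aorta (strain Wistar) for inhibition, with Thoracic aorta (Rattus norvegicus) as the target; a lower number here means a stronger inhibitor, a higher number a weaker inhibitor:

Compound 1, `COc1nc(-c2cc3ccccc3o2)cc(-c2ccc(C)cc2)c1C#N`: 266000 nM
Compound 2, `CCOc1nc(-c2cc3ccccc3o2)cc(-c2ccc(C)cc2)c1C#N`: 290000 nM
Compound 3, `COc1ccc(-c2cc(-c3cc4ccccc4o3)nc(OC)c2C#N)cc1`: 262000 nM

Compound 2 differs from compound 1 by methyl in place of hydrogen on a saturated chain carbon bound to an oxygen on an aromatic ring. That change gave a 1.1-fold higher number from compound 1 to compound 2 (0.04 log units; within the scatter), so the two values are indistinguishable. Compound 3 differs from compound 1 by methoxy in place of methyl on an aromatic carbon, and here a 1.0-fold lower number from compound 1 to compound 3 (0.01 log units; within the scatter), again indistinguishable.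

Compound 4, `CCOc1nc(-c2cc3ccccc3o2)cc(-c2ccc(OC)cc2)c1C#N`, has not yet been measured. It differs from compound 3 by methyl in place of hydrogen on a saturated chain carbon bound to an oxygen on an aromatic ring, the same change as from compound 1 to compound 2, made at the same kind of place. Since that earlier change left the number essentially where it was, compound 4 is expected to behave alike, with an estimated 1.1-fold higher number from compound 3 to compound 4 (0.03 log units; within the scatter) in this assay because a 1.1-fold higher number from compound 1 to compound 2 (0.04 log units; within the scatter). Compound 4 is therefore estimated at 280000 nM, between 150000 nM and 520000 nM.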

Compound 4, half-maximal inhibitory concentration: 204000 nM
For compound 4 the middle estimate is 1.4-fold (0.14 log units) above the measured one; measured number inside the range.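

In this assay, putting ethoxy in place of methoxy gave a 1.3-fold lower number from compound 3 to compound 4 (0.11 log units; within the scatter), which agrees with the same change on the other core: the same change on two cores in this assay, a 1.1-fold higher number (0.04 log units; within the scatter) from compound 1 to compound 2 and a 1.3-fold lower number (0.11 log units; within the scatter) from compound 3 to compound 4, 1.4-fold (0.15 log units) apart, within the scatter of two such steps. Methoxy in place of methyl gave a 1.4-fold lower number from compound 2 to compound 4 (0.15 log units; within the scatter), and this also agrees with its earlier step: the same change on two cores in this assay, a 1.0-fold lower number (0.01 log units; within the scatter) from compound 1 to compound 3 and a 1.4-fold lower number (0.15 log units; within the scatter) from compound 2 to compound 4, 1.4-fold (0.15 log units) apart, within the scatter of two such steps. For the compounds shown here, each change therefore behaved alike on the two cores, but all of these steps are within the scatter, so this shows only that neither change moved the number measurably on either core, not that either change has an effect that carries over, or that the same would hold on other cores.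

On these data alone, what a chain longer than ethyl, or an amine in place of the ethoxy group, would do remains open. As far as these compounds go, it also remains open whether any change to this series can move the number beyond the scatter.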